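This account rests on a few compounds, and the source may have more. Where it says the series, first, only, none or still open, it means among the compounds named here.

Compound 2 `O=C(O)CSc1ccc(NCc2cccc(Oc3ccccc3)c2)cc1` gives 324 nM in a functional assay on CHO cells for agonist activity at Free fatty acid receptor 1 (Homo sapiens) (a lower number here means that less compound is needed, a higher number that more compound is needed for the effect), and stands as the only numerical result in the set. Compound 1 `Cc1nc(-c2ccc(C(F)(F)F)cc2)sc1CNc1ccc(CCCC(=O)O)cc1` gives only a limit in this assay, namely < 10000 nM, which is the limit of < 10000 nM in this assay, at which 1 of the 2 values shown sits. Compound 3 `CC(C)NC(=O)CCc1ccc(NCc2cccc(Oc3ccccc3)c2)cc1` is not yet measured; it differs from compound 2 by 2-(isopropylcarbamoyl)ethyl in place of (carboxymethyl)sulfanyl on an aromatic carbon. Within the data shown here, no step between measured compounds is available to calibrate this change. In this assay a clear loss beyond the scatter is expected, an 11-fold higher number from compound 2 to compound 3 (1.03 log units; beyond the scatter). Compound 3 is estimated at 3500 nM, within 800 nM to 15000 nM.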

Compound 3, half-maximal effective concentration: 39.8 nM
The estimate for compound 3 lay 88-fold (1.94 log units) above the measured number; the whole stated range lies above it.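

On this aromatic carbon, para to a large group, 2-(isopropylcarbamoyl)ethyl in place of (carboxymethyl)sulfanyl gives an 8.1-fold lower number from compound 2 to compound 3 (0.91 log units; beyond the scatter) in this assay. In this pair, the carboxylic acid of the (carboxymethyl)sulfanyl group is therefore not required for activity, and the position accepts the larger chain. Nothing available explains this step.

Going by these compounds, whether the isopropyl group, the amide hydrogen or the ethyl chain carries the change stays open, and a tertiary amide or a shorter chain here would separate them. Compound 1 gives only a limit, < 10000 nM, and differs from the others in more than one place.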